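A few compounds are considered here, and "the series" means these few. Any claim that something is new, unique, unknown or untested is made for them only; others in the source may bear on it.

The series shares one core, and its members differ at the group attached to a double-bonded ring carbon of that core. Compound 1 `Cc1ccc(NC2=CC(=O)c3nc4n(c3C2=O)[C@H]2OC[C@@H](O)[C@H]2OC4)cc1` carries a 4-methylphenyl group joined through an amine there, and in a functional assay on ECa-109 cells for inhibition, with ECa-109 cell line (Homo sapiens) as the target, read by sulforhodamine B assay (on this read-out lower numbers stand for stronger inhibition and higher numbers for weaker inhibition), compound 1 gives 3480 nM. Compound 2 `O=C1C(Nc2cccc(Cl)c2)=CC(=O)c2c1nc1n2[C@H]2OC[C@@H](O)[C@H]2OC1` carries a (3-chlorophenyl)amino group; in this assay compound 2 gives 3080 nM, a number that sits within the usual scatter of the value of compound 1, so the two cannot be told apart. Compound 3 `O=C1C(N2CCCCC2)=CC(=O)c2c1nc1n2[C@H]2OC[C@@H](O)[C@H]2OC1` carries a piperidin-1-yl group, and in this assay compound 3 reports only a limit, > 8000 nM. Among the compounds with values here, the one measured step, an at least 2.5-fold higher number from compound 2 to compound 3 (0.41 log units; beyond the scatter), rests on that limit (the limit of > 8000 nM in this assay, at which 1 of the 3 values shown sits), so it shows only that removing the aromatic amine group weakens inhibition by that amount or more.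

Compound 4 `O=C1C=C(Nc2ccc(C(F)(F)F)cc2)C(=O)c2c1nc1n2[C@H]2OC[C@@H](O)[C@H]2OC1` differs from compound 1 by trifluoromethyl in place of methyl on an aromatic carbon. Within the data shown here, no measured step exchanges one substituent on the aromatic amine ring for another; the step from compound 2 to compound 3 removes the ring altogether and does not bear on this exchange, while compound 1 and compound 2, which differ in their ring substituent, sit within the scatter of each other. The expected change is therefore a 1.0-fold higher number from compound 1 to compound 4 (0.00 log units; within the scatter), within the scatter. The estimate for compound 4 in this assay is 3500 nM, in the range 1500 nM to 8000 nM.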

Compound 4, half-maximal inhibitory concentration: 5500 nM
Compound 4: the middle estimate sits 1.6-fold (0.20 log units) below what was measured; measured number inside the range.
By their numbers in this assay, from the lowest: compounds 2, 1 and 4 (each within the scatter of the next). At a limit, above all of these: compound 3.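

Trifluoromethyl in place of methyl on an aromatic carbon, para to a large group, gives in this assay a 1.6-fold higher number from compound 1 to compound 4 (0.20 log units; within the scatter), so this exchange cannot be told apart from no change at all. Unlike the earlier step, which took the aromatic ring away altogether, this step keeps the ring and its amine link and changes only the group on the ring, so it is the first direct reading of how the number responds to a substituent at this place. For this one pair, four heavy atoms can stand where one stood without a change beyond the scatter, although a single exchange cannot show that this holds for other groups on the ring.

Nothing given here bears on why this pair behaves as it does. Going by these compounds, it remains open whether a group of another kind at this same place on the ring, such as a carboxylic acid, an amine or a longer chain such as butyl, would move the number beyond the scatter in either direction.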